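Capping the Amine: From Open Sulfamoyl Groups to a Ring

The compounds below may be only part of what the source reports. "The series", "measured", "known", "first", "only" and "open" are said of these compounds alone.

Measured so far:
- compound 1, `NC[C@@H]1CCCc2cc(S(=O)(=O)c3cccc(F)c3)ccc21`: 0.0794 nM
- compound 2, `CN(C[C@@H]1CCCc2cc(S(=O)(=O)c3cccc(F)c3)ccc21)S(N)(=O)=O`: 3.98 nM
- compound 3, `CN(C)S(=O)(=O)NC[C@@H]1CCCc2cc(S(=O)(=O)c3cccc(F)c3)ccc21`: 2 nM

The read-out is an assay on isolated protein for displacement of a labelled ligand from 5-hydroxytryptamine receptor 6 (Homo sapiens); on this read-out higher numbers stand for weaker inhibition and lower numbers for stronger inhibition. Compound 3 stands second highest of the three numbers; its nearest neighbour is compound 2, with a 2.0-fold lower number from compound 2 to compound 3 (0.30 log units; within the scatter), and its furthest is compound 1, with a 25-fold higher number from compound 1 to compound 3 (1.40 log units; beyond the scatter).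

Compound 4, `O=S(=O)(c1cccc(F)c1)c1ccc2c(c1)CCC[C@H]2CN1CCCS1(=O)=O`, has not been measured. It differs from compound 3 in one place: a group of 7 heavy atoms (3 carbon, 1 nitrogen, 2 oxygen, 1 sulfur; one five-membered non-aromatic ring with 2 hetero atoms) in place of a group of 7 heavy atoms (2 carbon, 2 nitrogen, 2 oxygen, 1 sulfur; no ring), on a saturated chain carbon bound to a saturated ring carbon. The new group again covers the nitrogen that in compound 1 is a free amine, as the groups in compound 2 and compound 3 do.

Among the compounds with values here, two measured steps bear on this. Covering that nitrogen gave a 50-fold higher number from compound 1 to compound 2 (1.70 log units; beyond the scatter) and a 25-fold higher number from compound 1 to compound 3 (1.40 log units; beyond the scatter), both large. Exchanging one covering group for another gave a 2.0-fold lower number from compound 2 to compound 3 (0.30 log units; within the scatter), within the scatter. The change to compound 4 is of the second kind, so the expectation is a step of a 1.5-fold higher number from compound 3 to compound 4 (0.18 log units; within the scatter), not beyond the scatter. For compound 4 the expected value in this assay is 3 nM, with a range from 0.8 nM to 12 nM.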

Compound 4, inhibition constant: 31.6 nM
Estimate against measurement, compound 4: 11-fold (1.02 log units) below; the whole stated range lies below it.
By their numbers in this assay, from the lowest: compound 1; then compounds 3 and 2 (each within the scatter of the next); then compound 4.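

In this assay, the groups covering this nitrogen turn out not to be interchangeable: the two open sulfamoyl groups stayed within the scatter of each other, but the ring form gives a 16-fold higher number from compound 3 to compound 4 (1.20 log units; beyond the scatter) and a 7.9-fold higher number from compound 2 to compound 4 (0.90 log units; beyond the scatter). The group that leaves compound 3 and the group that enters have the same number of heavy atoms, so that number alone does not track the value at this place; the entering group has a ring and 0 hydrogen-bond donors. Against the free amine, this is the largest step seen here, a 400-fold higher number from compound 1 to compound 4 (2.60 log units; beyond the scatter).

Nothing available explains the rise. On these data alone, whether the ring or the missing donor matters stays open; a six-membered ring, or an open ethylsulfonylamino group, at this place could help separate the two.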